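The compounds below may be only part of what the source reports. "The series", "measured", "known", "first", "only" and "open" are said of these compounds alone.

Measured so far in a physicochemical assay on A549 cells for solubility, read by microscopy, with a stated time of 24 h; on this read-out lower numbers stand for stronger inhibition and higher numbers for weaker inhibition:
- compound 1 `O=C(N/N=C/c1ccco1)c1cc(-c2ccccc2)nn1Cc1ccc(Cl)nc1` gives 19400 nM
- compound 2 `O=C(N/N=C/c1ccccc1O)c1cc(-c2ccc(Cl)cc2)nn1Cc1ccc(Cl)nc1` gives 500 nM
- compound 3 `COc1ccc(/C=N/NC(=O)c2cc(-c3ccc(Cl)cc3)nn2Cc2ccc(Cl)nc2)cc1` gives "not determined" (no result reported)

Compound 3 stands without a number on this assay: no value was obtained, so it offers no anchor of its own. Compound 4 `O=C(N/N=C/c1ccco1)c1cc(-c2ccc(Cl)cc2)nn1Cc1ccc(Cl)nc1` is reached from compound 3 by one change, (furan-2-yl in place of 4-methoxyphenyl on a carbon with a double bond to nitrogen), that is, furan-2-yl in place of 4-methoxyphenyl on a carbon with a double bond to nitrogen. Going by the values given here, no measured pair shows this step, so its size and direction cannot be read from the data. What the two numbers show is a wide spread: in this assay compound 1, which also carries furan-2-yl, gives 19400 nM, while compound 2 gives 500 nM. Compound 4 shares parts of both, and its value is expected to fall between them, closer to the weaker end because compound 1 gives 19400 nM. Compound 4 is therefore estimated at 6000 nM, in a range from 1200 nM to 25000 nM.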

Compound 4, half-maximal inhibitory concentration: 9820 nM
Estimate against measurement, compound 4: 1.6-fold (0.21 log units) below; the measured number falls inside the stated range.
By their numbers in this assay, from the lowest: compound 2; then compounds 4 and 1 (each within the scatter of the next).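

In this assay, the carbon with a double bond to nitrogen emerges as a sensitive place: furan-2-yl in place of 2-hydroxyphenyl gives a 20-fold higher number from compound 2 to compound 4 (1.29 log units; beyond the scatter). Chloro in place of hydrogen on an aromatic carbon, by contrast, gives a 2.0-fold lower number from compound 1 to compound 4 (0.30 log units; within the scatter), so the two furan-2-yl compounds do not separate on this read-out. Nothing shown gives a measured reason for the large step.

Compound 3 has no number, and the step between 4-methoxyphenyl and furan-2-yl cannot be read, so only 2-hydroxyphenyl and furan-2-yl can be compared at this place. As far as these compounds go, how an amine, a carboxylic acid or a plain phenyl ring on this carbon would read in this assay stays open.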